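Swapping the aryl group on the shared core

This account rests on a few compounds, and the source may have more. Where it says the series, first, only, none or still open, it means among the compounds named here.

Compound 1 `CSc1ccc(C2=C(c3ccc(C)c(C)c3)C(=O)N3CCCC3C2)cc1` is the reference point. In a functional assay on U-251 cells (Homo sapiens) for cytotoxicity (on this read-out lower numbers stand for stronger inhibition of growth and higher numbers for weaker inhibition of growth), compound 1 gives 10000 nM, the highest of the two numbers recorded, with compound 3 nearest. Compound 3 `CSc1ccc(C2=C(c3ccc(Br)cc3)C(=O)N3CCCC3C2)cc1` gives 7000 nM, and a 1.4-fold lower number from compound 1 to compound 3 (0.15 log units; within the scatter). Compound 2 `CSc1ccc(C2=C(c3ccc(O)cc3)C(=O)N3CCCC3C2)cc1` is reported only as a limit of this assay, namely > 100000 nM. The remaining step, an at least 14-fold lower number from compound 2 to compound 3 (1.15 log units; beyond the scatter), sets that limit apart.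

Compound 4 `CSc1ccc(C2=C(c3ccc(SC)cc3)C(=O)N3CCCC3C2)cc1` differs from compound 1 in that (4-(methylsulfanyl)phenyl in place of 3,4-dimethylphenyl on a double-bonded ring carbon). The step that bears on this change is a 1.4-fold lower number from compound 1 to compound 3 (0.15 log units; within the scatter), an exchange on the same double-bonded ring carbon that stayed within the scatter, so no step beyond the scatter is expected, and a 1.1-fold lower number from compound 1 to compound 4 (0.05 log units; within the scatter) is the estimated outcome. Compound 4 is therefore expected to give 9000 nM, within the range 3000 nM to 30000 nM.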

Compound 4, concentration for 50% growth inhibition: 5000 nM
Beside the measured number, compound 4's estimate is 1.8-fold (0.26 log units) above it; low and high end bracket the measured number.
By their numbers in this assay, from the lowest: compounds 4, 3 and 1 (each within the scatter of the next). At a limit, above all of these: compound 2.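

In this assay, a third aryl group on this double-bonded ring carbon stays level with the first two, a 2.0-fold lower number from compound 1 to compound 4 (0.30 log units; within the scatter) and a 1.4-fold lower number from compound 3 to compound 4 (0.15 log units; within the scatter), so 4-(methylsulfanyl)phenyl, 4-bromophenyl and 3,4-dimethylphenyl are not told apart here. Only the hydroxy group stands off, with methylsulfanyl in its place giving an at least 20-fold lower number from compound 2 to compound 4 (1.30 log units; beyond the scatter). The value of compound 2 is a limit, not a number: the limit of > 100000 nM in this assay, at which 1 of the 4 values shown sits.

On these data alone, whether an amine or a carboxylic acid on this aromatic ring would track hydroxy or methylsulfanyl remains open. So does the effect of a longer chain on the sulfur.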